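The source may hold more compounds than are shown below. What is called first, only, known or untested is meant among the compounds shown, and "the series" means these compounds.

Compound 1 `CCCC[C@]1(CC)CS(=O)(=O)c2ccc(OC)cc2[C@@H](c2ccccc2)[C@H]1O`: 55 nM
Compound 2 `C=CCCCCCCCCOc1ccc2c(c1)S(=O)(=O)C[C@@](CC)(CCCC)[C@H](O)[C@@H]2c1ccccc1`: 16000 nM

Both compounds were tested in an assay on cells for inhibition of ileal sodium/bile acid cotransporter (Homo sapiens); on this read-out higher numbers stand for weaker inhibition and lower numbers for stronger inhibition. Compound 1 gives the lower of the two numbers, 55 nM, while compound 2 gives 16000 nM, a gap well beyond the usual scatter. Compound 3 `CCCCCCNc1ccc2c(c1)[C@@H](c1ccccc1)[C@@H](O)[C@](CC)(CCCC)CS2(=O)=O` has not yet been measured. It differs from compound 1 in one place: hexylamino in place of methoxy on an aromatic carbon. The much higher number of compound 2, 16000 nM, suggests that a larger group here can cost inhibition. A move toward weaker inhibition is therefore expected, with an estimated step of a 7.3-fold higher number from compound 1 to compound 3 (0.86 log units; beyond the scatter). Compound 3 is expected to give about 400 nM, within a range from 60 nM to 3000 nM.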

Compound 3, half-maximal inhibitory concentration: 1670 nM
Compound 3: middle estimate off by 4.2-fold (0.62 log units), on the low side; low and high end bracket the measured number.
By their numbers in this assay, from the lowest: compound 1; then compound 3; then compound 2.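

In this assay, hexylamino in place of methoxy on this aromatic carbon gives a 30-fold higher number from compound 1 to compound 3 (1.48 log units; beyond the scatter) and thus a large loss of inhibition from one change at this position. That change adds both a longer chain and a hydrogen-bond donor, and the step cannot separate the two. No measurement shown explains the loss. Still open, going by these compounds, is whether a plain amino group or a shorter chain on the nitrogen, such as ethylamino, would bring the number back toward that of compound 1.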